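Acetyl to benzoyl on the shared indole-derived core

A few compounds are considered here, and "the series" means these few. Any claim that something is new, unique, unknown or untested is made for them only; others in the source may bear on it.

Of the compounds shown here, two have been measured in a functional assay on LOX IMVI cells (Homo sapiens) for inhibition, read by sulforhodamine B assay, with a stated time of 48 h; on this read-out higher numbers stand for weaker inhibition of growth and lower numbers for stronger inhibition of growth. Compound 1 `COc1ccc(-c2[nH]c3ccc(OC)cc3c2/C=C(\C#N)S(=O)(=O)c2ccccc2)cc1` gives 1200 nM. Compound 2 `CC(=O)/C(=C\c1c(-c2ccccc2)[nH]c2ccccc12)S(=O)(=O)c1ccccc1` gives 1400 nM, the higher of the two numbers, but its gap to compound 1 lies within the scatter, so the two stand together rather than in any order. Compound 3 `O=C(/C(=C\c1c(-c2ccccc2)[nH]c2ccccc12)S(=O)(=O)c1ccccc1)c1ccccc1` has not yet been measured. It differs from compound 2 in one place: phenyl in place of methyl on a carbonyl carbon. Within the data shown here, no measured pair shows this change, and compounds 1 and 2 differ from each other in several places at once, so nothing measured sizes the step. The two measured numbers sit within scatter despite those differences, which gives no reason to expect the step to break the scatter in either direction. The expected step of a 1.1-fold lower number from compound 2 to compound 3 (0.03 log units; within the scatter) is accordingly taken as none beyond the scatter. Compound 3 is expected to give 1300 nM, in the range 500 nM to 3500 nM.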

Compound 3, concentration for 50% growth inhibition: 74700 nM
Compound 3: the middle estimate sits 57-fold (1.76 log units) below what was measured, and the stated range ends below it.
By their numbers in this assay, from the lowest: compounds 1 and 2 (each within the scatter of the next); then compound 3.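

At the carbonyl carbon whose other neighbour is the double-bonded chain carbon, the group is not interchangeable: in this assay, acetyl to benzoyl gives a 53-fold higher number from compound 2 to compound 3 (1.73 log units; beyond the scatter), well beyond the scatter. Among these compounds, this is the only one-place step, and it shows that growth inhibition at this position depends strongly on what the carbonyl carries, which compounds 1 and 2, differing in several places at once, could not show. Nothing at hand accounts for the size of this step.

Open, as far as these compounds go, is how the read-out moves between methyl and phenyl at this carbonyl carbon, for instance with ethyl, cyclopropyl or a longer chain. Also open, from the compounds shown here alone, is how an amine or a methoxy group in that place would read, and whether a phenyl bearing a fluorine would recover any of the lost inhibition.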